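Chromone amide series: nitro for tert-butyl on the benzamide ring

The compounds below may be only part of what the source reports. "The series", "measured", "known", "first", "only" and "open" are said of these compounds alone.

Compound 1, `CN(C)c1ccc(C(=O)Nc2cccc(NC(=O)COc3ccc4c(c3)NC(=O)CC4)c2)cc1`, in an assay on isolated protein for inhibition of Rho-associated protein kinase 2 (Homo sapiens), read by scintillation counting, radiometric assay and 33P incorporation, with a stated time of 40 min, in the presence of a further agent that is not named here (a lower number here means a stronger inhibitor, a higher number a weaker inhibitor), gives 3140 nM.
Compound 2, `CC(C)(C)c1ccc(C(=O)Nc2cccc(NC(=O)COc3ccc4c(=O)ccoc4c3)c2)cc1`, in this assay gives 34 nM.

Going by the values given here, compound 2 holds the lowest number of the two measured in this assay; compound 1 stands higher, beyond the scatter, though the two differ in core as well as in the substituent on the benzamide ring, so the pair yields no single-point step.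

Compound 3, `O=C(COc1ccc2c(=O)ccoc2c1)Nc1cccc(NC(=O)c2ccc([N+](=O)[O-])cc2)c1`, is not yet measured. It differs from compound 2 in one place: nitro in place of tert-butyl on an aromatic carbon, para to a large group. Among the compounds with values here, no measured pair isolates this change. The expectation is a moderate loss of potency in this assay, a step of a 2.6-fold higher number from compound 2 to compound 3 (0.42 log units; beyond the scatter) from compound 2 to compound 3, beyond the scatter but not large. Compound 3 is therefore estimated at 90 nM, with a range of 25 nM to 400 nM.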

Compound 3, half-maximal inhibitory concentration: 15 nM
The estimate for compound 3 lay 6.0-fold (0.78 log units) above the measured number, and the stated range ends above it.
By their numbers in this assay, from the lowest: compound 3; then compound 2; then compound 1.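

Going by these compounds alone, this is the first one-place comparison: in this assay, nitro in place of tert-butyl on the aromatic carbon para to a large group gives a 2.3-fold lower number from compound 2 to compound 3 (0.36 log units; beyond the scatter), a modest step beyond the scatter. This position therefore accepts the exchange of a group of four carbons and no hydrogen-bond acceptors for one with two hydrogen-bond acceptors, and the number falls rather than rises. No measurement at hand bears on why the number moves in this direction.

Within the data shown here, with only two groups compared on this carbon, no trend can be drawn, and whether an amine or a carboxylic acid here would keep the number as low remains open. Compound 1 differs from both other compounds in core as well as substituent, so the contribution of the core remains unseparated.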